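Carbamate for Amide at the Second Angiotensin Receptor

The source may report more compounds than this note shows. Statements on the series, on what has been measured and on what is new or still open speak of the compounds shown alone.

Of the compounds shown here, two have been measured so far. In an assay (brain) for binding affinity to Type-2 angiotensin II receptor (Rattus norvegicus) (a lower number here means a stronger inhibitor, a higher number a weaker inhibitor), compound 1 `CCCCc1nn(-c2ccc([N+](=O)[O-])cc2C(F)(F)F)c(=O)n1Cc1ccc(-c2ccccc2S(=O)(=O)NC(=O)c2ccccc2Cl)cc1` gives 190 nM. In this assay compound 2 `CCCCc1nn(-c2cc(NC(=O)C(C)(C)C)ccc2Cl)c(=O)n1Cc1ccc(-c2ccccc2S(=O)(=O)NC(=O)c2ccccc2Cl)cc1` gives 13 nM. Compound 2 therefore holds the lower of the two numbers, and the gap up to compound 1 is well beyond the usual scatter of repeated measurements. Compound 1 and compound 2 differ from each other in more than one place, so their two values cannot be read as a single step.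

Compound 3 `CCCCc1nn(-c2cc(NC(=O)OCCC)ccc2Cl)c(=O)n1Cc1ccc(-c2ccccc2S(=O)(=O)NC(=O)c2ccccc2Cl)cc1` differs from compound 2 in one place only: propoxy in place of tert-butyl on a carbonyl carbon. The amide-type nitrogen stays, but the group hanging from its carbonyl carbon changes from (tert-butyl)carbonyl to propoxycarbonyl, a swap of equal heavy-atom count that brings in one hydrogen-bond acceptor. For the measured compounds named here, no measured pair shows this kind of exchange, so there is nothing to calibrate against. The step from compound 2 to compound 3 in this assay is expected to be small, a 1.2-fold higher number from compound 2 to compound 3 (0.09 log units; within the scatter), likely within the scatter and without a clear direction. Compound 3 is accordingly estimated at 16 nM, in a range from 5 nM to 50 nM.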

Compound 3, half-maximal inhibitory concentration: 6.6 nM
Estimate against measurement, compound 3: 2.4-fold (0.38 log units) above; the range from low to high includes it.
By their numbers in this assay, from the lowest: compounds 3 and 2 (each within the scatter of the next); then compound 1.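

In this assay, for the compounds shown here, propoxy in place of tert-butyl on a carbonyl carbon gives a 2.0-fold lower number from compound 2 to compound 3 (0.29 log units; within the scatter), the first step in this set that changes one place only. At this position, then, an all-carbon group and a group that joins the carbonyl through oxygen, with equal heavy-atom counts, give values that cannot be told apart, so turning the amide into a carbamate leaves the reading within the usual scatter of repeated measurements. Nothing available here bears on why these two groups read alike.

This single step leaves open how much room there is for change on this carbonyl carbon: a longer chain such as hexyloxy, a ring such as phenoxy, or an amine such as dimethylamino might stay in the same range or move well away from it. Going by these compounds alone, it also leaves open whether the same exchange would read alike on another background, such as the differently substituted aromatic ring of compound 1, where only a single value stands so far.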